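The source may report more compounds than this note shows. Statements on the series, on what has been measured and on what is new or still open speak of the compounds shown alone.

Compound 2 `CC1(/N=C(\NC#N)Nc2cccnc2)CCC1` gives 50 mg/kg in a functional assay on the whole organism (blood, strain Wistar-Okamoto) with Rattus norvegicus as the target, with a stated time of 5 days (on this read-out higher numbers stand for an effect only at larger amounts of compound and lower numbers for an effect already at smaller amounts), the highest of the two numbers recorded so far. Within the data shown here, its nearest neighbour is compound 1 `CC(C)C/N=C(\NC#N)Nc1cccnc1`, which in this assay gives 20 mg/kg; the only step measured, a 2.5-fold higher number from compound 1 to compound 2 (0.40 log units; beyond the scatter), puts 1-methylcyclobutyl in place of isobutyl on a double-bonded nitrogen. Compound 3 `N#CN/C(=N\Cc1ccco1)Nc1cccnc1` remains to be measured. It differs from compound 2 by (furan-2-yl)methyl in place of 1-methylcyclobutyl on a double-bonded nitrogen. Among the measured compounds shown here, the one step in hand concerns the same double-bonded nitrogen and shows that exchanging the group there moves the read-out modestly, yet beyond the scatter; no measured step covers an aromatic group at this place, so the direction for compound 3 cannot be read from the data. For the measured compounds named here, a modest shift, in either direction, is the most that the single precedent supports. Compound 3 is therefore expected to give about 30 mg/kg in this assay, with a range of 10 mg/kg to 100 mg/kg. This estimate corresponds to an expected step of a 1.7-fold lower number from compound 2 to compound 3 (0.22 log units; within the scatter), which stays close to the scatter.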

Compound 3, minimum effective dose: 20 mg/kg
For compound 3 the middle estimate is 1.5-fold (0.18 log units) above the measured one; the range from low to high includes it.
By their numbers in this assay, from the lowest: compounds 1 and 3 (each within the scatter of the next); then compound 2.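

The aromatic (furan-2-yl)methyl group is accepted on the double-bonded nitrogen in this assay and gives a 2.5-fold lower number from compound 2 to compound 3 (0.40 log units; beyond the scatter) as its step, so this place responds to a ring-bearing group and not only to open or small saturated carbon groups, and the two steps from compound 2 to the others now leave compound 2 alone at the high end of the read-out. Among these compounds, the comparison with the isobutyl compound gives no change at the digits printed from compound 1 to compound 3 (within the scatter) as its step, which means that on the saturated chain carbon bound to a double-bonded nitrogen, furan-2-yl and isopropyl cannot be told apart in this read-out, and 1-methylcyclobutyl is so far the only group at this place that separates from the others. Nothing available explains either step.

Going by these compounds, whether the furan ring itself matters stays open, since phenylmethyl in place of (furan-2-yl)methyl would be needed to show it. A longer chain carrying the furan, or an amine on the chain at the same place, also remains to be placed against compound 1 and compound 3.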